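The compounds below may be only part of what the source reports. "The series", "measured", "known", "first", "only" and "open" are said of these compounds alone.

Of the compounds shown here, two that share one core have been measured so far in a functional assay on U-251 cells (Homo sapiens) for antiproliferative activity, read by MTT assay, with a stated time of 48 h (a lower number here means a stronger inhibitor, a higher number a weaker inhibitor), and they lie far apart. Compound 1 `COc1ccc(-c2nc3cccc(-c4cc(OC)c(OC)c(OC)c4)c3o2)cc1OC` gives 1300 nM while compound 2 `COc1cc(-c2cccc3nc(-c4cccc(Cl)c4)oc23)cc(OC)c1OC` gives 18500 nM as the higher of the two numbers, which makes compound 2 the weaker inhibitor of the pair. Among the measured compounds shown here, only one measured step bears on what comes next. It is a 14-fold higher number from compound 1 to compound 2 (1.15 log units; beyond the scatter) and it came with 3-chlorophenyl in place of 3,4-dimethoxyphenyl on an aromatic carbon. Compound 3 `COc1cc(-c2cccc3nc(-c4ccc(N)cc4)oc23)cc(OC)c1OC` changes that same group again, with 4-aminophenyl in place of 3-chlorophenyl on an aromatic carbon on that aromatic carbon. For the measured compounds named here, no measured compound carries 4-aminophenyl, so a single step is thin evidence. Going by the values given here, it does show that swapping this group can move the number a long way, and the only compound with 3-chlorophenyl has the higher number, so a fall is expected on leaving that group. The expected change is a 4.6-fold lower number from compound 2 to compound 3 (0.67 log units; beyond the scatter) and it remains a rough estimate. For compound 3 the estimated value is 4000 nM with 700 nM and 20000 nM as the expected lower and upper ends.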

Compound 3, half-maximal inhibitory concentration: 1040 nM
Compound 3: the middle estimate sits 3.8-fold (0.59 log units) above what was measured; the range from low to high includes it.
By their numbers in this assay, from the lowest: compounds 3 and 1 (each within the scatter of the next); then compound 2.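

In this assay, the aromatic carbon next to the ring nitrogen and next to the ring oxygen now shows a second large step, an 18-fold lower number from compound 2 to compound 3 (1.25 log units; beyond the scatter), so the earlier swing at this place was not a one-off tied to the 3,4-dimethoxyphenyl group. The comparison between the two non-chlorinated groups adds something new: a 1.3-fold lower number from compound 1 to compound 3 (0.10 log units; within the scatter), which means that 4-aminophenyl and 3,4-dimethoxyphenyl, though they are different groups, cannot be told apart here, and among these three compounds only the one with 3-chlorophenyl stands apart. No measurement at hand explains why this one group separates from the other two.

The two groups exchanged between compound 2 and compound 3 differ both in the atom attached to the phenyl ring and in its numbered place on that ring, so the compounds shown cannot say which of these changes goes with the large step. A 4-chlorophenyl group, a 3-aminophenyl group or a plain phenyl group on the same carbon would pull these two changes apart.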